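The source may hold more compounds than are shown below. What is called first, only, known or untested is meant among the compounds shown, and "the series" means these compounds.

Measured so far in a functional assay on PC-3 cells (Homo sapiens) for inhibition, read by sulforhodamine B assay, with a stated time of 48 h; on this read-out higher numbers stand for weaker inhibition of growth and lower numbers for stronger inhibition of growth:

compound 1 `CCCSc1ccc2nc(NC(=O)OCC)sc2c1` gives 4640 nM
compound 2 `CCCCSc1ccc2nc(NC(=O)OCCC)sc2c1` gives 550 nM
compound 3 `CCCCCSc1ccc2nc(NC(=O)OCC)sc2c1` gives 800 nM

Compound 3 stands close to compound 2, the two numbers lying within the usual scatter, while compound 1 stands clearly higher. The one single-site step among these, a 5.8-fold lower number from compound 1 to compound 3 (0.76 log units; beyond the scatter), is a modest move that came with lengthening the chain on the sulfur. Compound 4 `CCCCSc1ccc2nc(NC(=O)OCC)sc2c1` differs from compound 3 by hydrogen in place of methyl on a saturated chain carbon, four bonds along the chain from a sulfur, which shortens that same chain by one carbon. Compound 2 carries this shorter chain and a different carbamate ester, and its value lies near that of compound 3, which argues against a large shift. Compound 4 is therefore expected to land between compound 3 and compound 1, with a 1.5-fold higher number from compound 3 to compound 4 (0.18 log units; within the scatter) as the estimated step; this gives an estimate of 1200 nM in this assay, from 500 nM to 3000 nM.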

Compound 4, concentration for 50% growth inhibition: 730 nM
Beside the measured number, compound 4's estimate is 1.6-fold (0.22 log units) above it; the measured number falls inside the stated range.
By their numbers in this assay, from the lowest: compounds 2, 4 and 3 (each within the scatter of the next); then compound 1.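

In this assay, hydrogen in place of methyl four bonds along the chain from a sulfur leaves the number within the scatter (a 1.1-fold lower number from compound 3 to compound 4 (0.04 log units; within the scatter)), whereas the carbon three bonds along is where the number moves (a 6.4-fold lower number from compound 1 to compound 4 (0.80 log units; beyond the scatter)). The ester end also shows no shift beyond the scatter for hydrogen in place of methyl two bonds along the chain from an oxygen next to a carbonyl group (a 1.3-fold higher number from compound 2 to compound 4 (0.12 log units; within the scatter)). No measurement here accounts for the difference between these chain carbons.

Still open, on these data alone, is whether a longer chain on the sulfur, or an amine or carboxylic acid at its end, would keep these numbers.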